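Cytotoxicity notes on a bis-piperazine amide series

A few compounds are considered here, and "the series" means these few. Any claim that something is new, unique, unknown or untested is made for them only; others in the source may bear on it.

Compound 1 `Cc1ccc(C(=O)N2CCN(CC(=O)N3CCN(CCCc4c[nH]c5ccccc45)CC3)CC2)cc1` is the reference point of this set. In an ADME assay on HEK293 cells (Homo sapiens) for cytotoxicity, read by MTT assay, with a stated time of 72 h (a lower number here means a stronger inhibitor, a higher number a weaker inhibitor), compound 1 gives 159000 nM. Compound 2 `O=C(CN1CCN(C(=O)c2ccc(F)cc2)CC1)N1CCN(CCCc2c[nH]c3ccccc23)CC1` carries the change (fluoro in place of methyl on an aromatic carbon); in this assay compound 2 gives 141000 nM, and the step is a 1.1-fold lower number from compound 1 to compound 2 (0.05 log units; within the scatter). Compound 3 `Cc1ccc(C(=O)N2CCN(CC(=O)N3CCN(CCCc4c[nH]c5ccc(F)cc45)CC3)CC2)cc1` differs from compound 1 in the core, the difference being (fluoro in place of hydrogen on an aromatic carbon). In this assay compound 3 gives 141000 nM, a step of a 1.1-fold lower number from compound 1 to compound 3 (0.05 log units; within the scatter). Compound 2 and compound 3 stand level at the digits read, and all three numbers lie within the usual scatter of one another, so no order among them is claimed here.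

Compound 4 `O=C(CN1CCN(C(=O)c2ccc(F)cc2)CC1)N1CCN(CCCc2c[nH]c3ccc(F)cc23)CC1` has not yet been measured. It differs from compound 3 by fluoro in place of methyl on an aromatic carbon, the same change as the one between compound 1 and compound 2; the change occurs twice among the compounds shown, the place is described in the same words in both cases, and only the cores differ, as told above. Because a 1.1-fold lower number from compound 1 to compound 2 (0.05 log units; within the scatter) stayed within the scatter, the same change on the core of compound 3 is expected to give a step of about a 1.1-fold lower number from compound 3 to compound 4 (0.04 log units; within the scatter) in this assay. For compound 4 the estimate in this assay is 130000 nM, with most repeats expected between 65000 nM and 260000 nM.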

Compound 4, half-maximal inhibitory concentration: 102000 nM
Estimate against measurement, compound 4: 1.3-fold (0.11 log units) above; the range from low to high includes it.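

In this assay the change from 4-methylphenyl to 4-fluorophenyl now reads twice, the new reading being a 1.4-fold lower number from compound 3 to compound 4 (0.14 log units; within the scatter), and the two readings do not differ beyond what repeats allow: the same change on two cores in this assay, a 1.1-fold lower number (0.05 log units; within the scatter) from compound 1 to compound 2 and a 1.4-fold lower number (0.14 log units; within the scatter) from compound 3 to compound 4, 1.2-fold (0.09 log units) apart, within the scatter of two such steps. The fluoro in place of hydrogen on an aromatic carbon also reads twice, the new reading being a 1.4-fold lower number from compound 2 to compound 4 (0.14 log units; within the scatter), with the same outcome: the same change on two cores in this assay, a 1.1-fold lower number (0.05 log units; within the scatter) from compound 1 to compound 3 and a 1.4-fold lower number (0.14 log units; within the scatter) from compound 2 to compound 4, 1.2-fold (0.09 log units) apart, within the scatter of two such steps. This shows that both changes carry between the two cores shown without a visible shift, but every step involved is itself within the scatter, so it does not show that either change has any effect here, nor how a step clearly beyond the scatter would carry from one core to another.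

As far as these compounds go, whether a larger step appears with a different group in place of the methyl of the 4-methylphenyl, such as a nitrile, an amine or a carboxylic acid, remains open, as does the effect of a longer chain in the shared core. From the compounds shown here alone, all of the readings come from this assay alone, and whether either change behaves the same way in any other read-out also remains open.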